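Ring-amine substituent swap from compound 1 to compound 4

The source may report more compounds than this note shows. Statements on the series, on what has been measured and on what is new or still open speak of the compounds shown alone.

Going by the values given here, compound 1 `Nc1scc(CN2CCN(c3ccc([N+](=O)[O-])cc3)CC2)c1C(=O)c1ccc(Cl)cc1` gives -12% in a functional assay on CHO cells with adenosine receptor A1 (Homo sapiens) as the target, read by cAMP accumulation and immunoassay, with a stated time of 6 min, tested at 0.01 uM (on this read-out lower numbers stand for a stronger effect and higher numbers for a weaker effect at the one concentration tested), the lowest of the three numbers measured so far. Compound 2 `Nc1scc(CN2CCN(c3ccccc3F)CC2)c1C(=O)c1ccc(Cl)cc1` gives 2.1% and compound 3 `Nc1scc(CN2CCN(c3ccc(F)c(Cl)c3)CC2)c1C(=O)c1ccc(Cl)cc1` gives 4.2%; the step of a number 2.1 percentage points higher from compound 2 to compound 3 (within the scatter) lies within the scatter. Both changes away from the 4-nitrophenyl went upward: a number 14.1 percentage points higher from compound 1 to compound 2 (beyond the scatter) and a number 16.2 percentage points higher from compound 1 to compound 3 (beyond the scatter). Compound 4 `Nc1scc(CN2CCN(CCCc3ccc(Cl)cc3)CC2)c1C(=O)c1ccc(Cl)cc1` differs from compound 1 by 3-(4-chlorophenyl)propyl in place of 4-nitrophenyl on an amine nitrogen in a ring. Among the compounds with values here, no measured step places a 3-(4-chlorophenyl)propyl here, so only the two aryl replacements bear on it; both were modest and upward, and a step of similar size in the same direction is expected, with wider uncertainty for the new group. Compound 4 is therefore estimated at 2% (range -12% to 16%), which means an expected step of a number 14 percentage points higher from compound 1 to compound 4 (beyond the scatter).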

Compound 4, a percentage reported as activity, at one concentration (the size of the read-out at that concentration, not a potency): 0%
Compound 4: middle estimate off by 2 percentage points, on the high side, and the stated range covers the measured number.
By their numbers in this assay, from the lowest: compound 1; then compounds 4, 2 and 3 (each within the scatter of the next).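

At this position, the step of a number 12 percentage points higher from compound 1 to compound 4 (beyond the scatter) in this assay shows that the shift away from compound 1 also occurs with a 3-(4-chlorophenyl)propyl group, so it is not confined to the two aryl replacements. The steps of a number 4.2 percentage points lower from compound 3 to compound 4 (within the scatter) and a number 2.1 percentage points lower from compound 2 to compound 4 (within the scatter) leave no separation among compounds 2, 3 and 4, and of these four only compound 1 stands apart. No supporting data on hand account for this.

Open, on these data alone, is whether a benzyl group or a longer chain carrying the same 4-chlorophenyl would stay level with compound 4. Also open, as far as these compounds go, is whether a nitrile in place of the nitro group would keep the number of compound 1.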